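Amide substituent series: compound 3 to compound 4

The source may hold more compounds than are shown below. What is called first, only, known or untested is meant among the compounds shown, and "the series" means these compounds.

Measured so far in an assay on HeLa cells for displacement of a labelled ligand from adenosine receptor A3 (Homo sapiens), read by scintillation counting, with a stated time of 180 min, tested at 10 uM; a lower number here means less inhibition, a higher number more inhibition at the concentration tested (going by the name of the read-out):
compound 1 `COCCNC(=O)c1cc2cccc(OC)c2oc1=N` gives 15%
compound 2 `COc1cccc2cc(C(=O)NCCO)c(=N)oc12` gives 23%
compound 3 `COc1cccc2cc(C(=O)NC3CCCCC3)c(=N)oc12` gives 16%

Compound 3 holds the second highest of the three numbers. Its nearest neighbour is compound 1, with a number 1 percentage points higher from compound 1 to compound 3 (within the scatter); the furthest is compound 2, with a number 7 percentage points lower from compound 2 to compound 3 (within the scatter). Neither step leaves the scatter, so the three compounds cannot be ordered on these numbers.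

Compound 4 `COc1cccc2cc(C(=O)NCCCCCO)c(=N)oc12` differs from compound 3 by 5-hydroxypentyl in place of cyclohexyl on an amide-type nitrogen. The step bearing most directly on this change is a number 7 percentage points lower from compound 2 to compound 3 (within the scatter), which swapped a hydroxyalkyl chain on the amide-type nitrogen for cyclohexyl without a change beyond the scatter. The step of a number 1 percentage points higher from compound 1 to compound 3 (within the scatter), also on the amide-type nitrogen, was likewise within the scatter. Among the compounds with values here, no measured step shows any substituent on the amide-type nitrogen moving this assay beyond its noise.

Accordingly compound 4 is expected to give 20%, with a range from 8% to 32%. The expected step is a number 4 percentage points higher from compound 3 to compound 4 (within the scatter), meaning no change beyond the scatter.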

Compound 4, a percentage reported as inhibition, at one concentration (the size of the read-out at that concentration, not a potency): 13%
Beside the measured number, compound 4's estimate is 7 percentage points above it; measured number inside the range.
By their numbers in this assay, from the lowest: compounds 4, 1, 3 and 2 (each within the scatter of the next).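

The open 5-hydroxypentyl chain in place of the cyclohexyl ring, measured in this assay, gives a number 3 percentage points lower from compound 3 to compound 4 (within the scatter) and so shows that removing the ring and adding a hydroxyl at the chain end does not shift the read-out beyond the noise. On the saturated chain, 3-hydroxypropyl in place of hydroxy gives a number 10 percentage points lower from compound 2 to compound 4 (within the scatter) and 3-hydroxypropyl in place of methoxy gives a number 2 percentage points lower from compound 1 to compound 4 (within the scatter) so extending the chain on the amide-type nitrogen also registers as no change. No substituent shown on this nitrogen has yet separated from any other, and no data bear on the cause of this.

As far as these compounds go, whether an amine or a carboxylic acid at the chain end, or a benzyl group on the nitrogen, would move the number beyond the scatter remains open. So does whether changes on the shared core would move it at all.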